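Aryl Ester Variation on a Shared Flavone Core

The source may report more compounds than this note shows. Statements on the series, on what has been measured and on what is new or still open speak of the compounds shown alone.

Of the compounds shown here, two built on a shared core have been measured in a functional assay on cells (T-cell, Mus musculus, strain BALB/c) for inhibition, read by MTT assay, with a stated time of 72 h; a lower number here means a stronger inhibitor, a higher number a weaker inhibitor. Compound 1 `COC(=O)c1cc(O)ccc1OC(=O)COc1cc(O)c2c(=O)cc(-c3ccccc3)oc2c1` gives 29500 nM. Compound 2 `COC(=O)c1cccc(Cl)c1OC(=O)COc1cc(O)c2c(=O)cc(-c3ccccc3)oc2c1` gives 38700 nM, the highest of the two numbers, with compound 1 the nearest; the step of a 1.3-fold higher number from compound 1 to compound 2 (0.12 log units; within the scatter) lies within the scatter.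

Compound 3 `COC(=O)c1cc(C)ccc1OC(=O)COc1cc(O)c2c(=O)cc(-c3ccccc3)oc2c1` has not yet been measured. It differs from compound 2 by a group of 11 heavy atoms (9 carbon, 2 oxygen; one six-membered aromatic ring of carbon only) in place of a group of 11 heavy atoms (8 carbon, 2 oxygen, 1 chlorine; one six-membered aromatic ring of carbon only), on an oxygen next to a carbonyl group. Among the compounds with values here, the only measured step that bears on this change is a 1.3-fold higher number from compound 1 to compound 2 (0.12 log units; within the scatter), which exchanged one aryl group on this same oxygen for another and produced nothing beyond the scatter. A further exchange of the aryl group at the same place is therefore expected to give no step beyond the scatter: a 1.1-fold lower number from compound 2 to compound 3 (0.04 log units; within the scatter). Compound 3 is estimated at 35000 nM, with a range from 15000 nM to 80000 nM.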

Compound 3, half-maximal inhibitory concentration: 25700 nM
Beside the measured number, compound 3's estimate is 1.4-fold (0.13 log units) above it; the measured number falls inside the stated range.
By their numbers in this assay, from the lowest: compounds 3, 1 and 2 (each within the scatter of the next).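

In this assay, the exchange of the 2-chloro-6-(methoxycarbonyl)phenyl group on an oxygen next to a carbonyl group gives a 1.5-fold lower number from compound 2 to compound 3 (0.18 log units; within the scatter), so a third aryl group at this place again produces no step beyond the scatter. The replacement of a single group, methyl in place of hydroxy on an aromatic carbon, gives a 1.1-fold lower number from compound 1 to compound 3 (0.06 log units; within the scatter), which shows that this simpler exchange also stays within the scatter. Nothing shown explains why these numbers remain so close.

All the aryl groups shown keep the methoxycarbonyl group, so it remains open whether a carboxylic acid in its place would move the number beyond the scatter. On these data alone, it also remains open whether an amine or a longer carbon chain on that aromatic carbon would do so.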